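Swapping the Hydroxyethyl Arm on a Shared Core

This account rests on a few compounds, and the source may have more. Where it says the series, first, only, none or still open, it means among the compounds named here.

Compound 1, `COc1ccc(NNCc2cc(O)n3nc(N)c([N+](=O)[O-])c3n2)cc1`: 5.1 ug/mL
Compound 2, `Nc1nn2c(O)cc(CNCCO)nc2c1[N+](=O)[O-]`: > 50 ug/mL

Both have been tested in a functional assay on K562 cells (Homo sapiens) for inhibition; on this read-out higher numbers stand for weaker inhibition of growth and lower numbers for stronger inhibition of growth. Compound 2 gives only > 50 ug/mL, which is a limit of the assay and not a number, as shown by the limit of > 50 ug/mL in this assay, at which 1 of the 2 values shown sits. Compound 3, `Nc1nn2c(O)cc(CNNC(N)S)nc2c1[N+](=O)[O-]`, differs from compound 2 by (amino(sulfanyl)methyl)amino in place of 2-hydroxyethyl on an amine nitrogen. Going by the values given here, no measured pair shows what this change does. Because compound 2 sits at the limit of > 50 ug/mL in this assay, at which 1 of the 2 values shown sits, a small move toward stronger inhibition is expected, within or just beyond the scatter, so the expected step is an at least 1.2-fold lower number from compound 2 to compound 3 (0.09 log units; that floor lies within the scatter). Compound 3 is therefore estimated at 40 ug/mL, between 10 ug/mL and 120 ug/mL.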

Compound 3, concentration for 50% growth inhibition: > 50 ug/mL
Compound 3: no number, only a limit; the forecaster's own chance of this, stated with the estimate: 55%; at least 1.2-fold (0.09 log units) between middle value and limit.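

In this assay compound 3 also stays at a limit of the assay, not a number (> 50 ug/mL). The swap of 2-hydroxyethyl for (amino(sulfanyl)methyl)amino on the amine nitrogen cannot be read, because both compounds sit at the same limit: the limit of > 50 ug/mL in this assay, at which 2 of the 3 values shown sit.
Amino(sulfanyl)methyl in place of 4-methoxyphenyl on an amine nitrogen gives an at least 9.8-fold higher number from compound 1 to compound 3 (0.99 log units; beyond the scatter) and so marks a clear loss of growth inhibition.

Still open, as far as these compounds go, is whether a plain phenyl or a longer chain on this amine nitrogen would keep the growth inhibition of compound 1.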